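Swapping a Nitrophenyl Arm for a Hydroxyphenyl One

The compounds below may be only part of what the source reports. "The series", "measured", "known", "first", "only" and "open" are said of these compounds alone.

Of the compounds shown here, three have been tested in a functional assay on MCF7 cells (Homo sapiens) for antiproliferative activity, read by MTT assay, with a stated time of 24 h, tested at 0.0001 ug/mL; a lower number here means a stronger effect, a higher number a weaker effect of the compound at the concentration tested. The first two are small: compound 1 `O=Cc1cn(-c2ccccc2)nc1-c1ccc([N+](=O)[O-])cc1` gives 106%, and compound 2 `O=Cc1cn(-c2ccccc2)nc1-c1cccc([N+](=O)[O-])c1` gives 89%. Compound 3 `COc1cc(/C=C/C(=O)C(=Cc2cn(-c3ccccc3)nc2-c2ccc([N+](=O)[O-])cc2)C(=O)/C=C/c2ccc(O)c(OC)c2)ccc1O` is a much larger molecule in which the shared core carries two long curcumin-like arms, and in this assay compound 3 gives 98%. On these numbers compound 3 sits close to both neighbours: the gap to compound 1 and the gap to compound 2 each lie within the usual scatter, so the three values cannot be told apart with confidence. All of them are close to the level that means no measurable effect at this very low concentration.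

Compound 4 `COc1cc(/C=C/C(=O)C(=Cc2cn(-c3ccccc3)nc2-c2ccccc2O)C(=O)/C=C/c2ccc(O)c(OC)c2)ccc1O` keeps everything in compound 3 except one group on the five-membered ring: 2-hydroxyphenyl in place of 4-nitrophenyl on an aromatic carbon. Among the compounds with values here, no measured pair in this set differs in exactly this way, so there is no step to lean on. Because compound 3 already shows 98%, and because compounds 1 and 2 with other ring substituents show nearly the same, the change is expected to move the number little, if at all, beyond the scatter.

The expected step of a number 1 percentage points lower from compound 3 to compound 4 (within the scatter) is therefore essentially flat. Compound 4 is estimated to give 97%, with a range from 83% to 111%.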

Compound 4, a percentage reported as activity, at one concentration (the size of the read-out at that concentration, not a potency): 100%
For compound 4 the middle estimate is 3 percentage points below the measured one; measured number inside the range.
By their numbers in this assay, from the lowest: compounds 2, 3, 4 and 1 (each within the scatter of the next, the first and the last beyond it).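

Within the data shown here, this is the first direct reading of a single change on the five-membered ring: with the shared core and the two long arms held fixed, 2-hydroxyphenyl in place of 4-nitrophenyl gives a number 2 percentage points higher from compound 3 to compound 4 (within the scatter) in this assay. At this position, next to the ring nitrogen, the read-out therefore does not separate the two groups at this very low concentration, even though the entering group is smaller by the count of heavy atoms and brings a hydrogen-bond donor that the leaving group lacks. No measured information is available to explain this flat result.

The compounds shown leave open whether an amine or a carboxylic acid on this same aromatic carbon would move the read-out by more than the usual scatter. They also leave open whether the swap from 4-nitrophenyl to 2-hydroxyphenyl would stay this flat at a concentration where the compounds produce a clear antiproliferative effect.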